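The source may report more compounds than this note shows. Statements on the series, on what has been measured and on what is new or still open speak of the compounds shown alone.

Measured compounds in a functional assay on B16-F10 cells (Mus musculus) for cytotoxicity; a lower number here means a stronger inhibitor, a higher number a weaker inhibitor:
compound 1 `O=c1oc2ccccc2c2nc3c(ccc4cc[nH]c43)c(-c3ccc(Br)cc3)c12` with 70700 nM;
compound 2 `O=c1cc(O)c2cc(Cl)ccc2o1` with 70700 nM;
compound 3 `O=c1oc2ccccc2c2nc3c(ccc4cc[nH]c43)c(-c3ccc(F)cc3)c12` with 70700 nM.

Compound 1 stands level with compounds 2 and 3 in this assay: the three values are the same at the digits shown, so none of them can be called stronger or weaker than another. Compounds 1 and 3 share one core and differ only at the aromatic carbon that carries the halogenated ring; the step of no change at the digits printed from compound 1 to compound 3 (within the scatter) shows that swapping one halogen for another there leaves the read-out where it was. Within the data shown here, compound 2 has a different and smaller structure, and no step to it is given; its value simply shows the same number as compound 1.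

Compound 4 `O=c1oc2ccccc2c2nc3c(ccc4cc[nH]c43)c(-c3cccc4ccccc34)c12` has not yet been measured in this assay. It differs from compound 1 at the same aromatic carbon that distinguishes compounds 1 and 3: naphthalen-1-yl in place of 4-bromophenyl on an aromatic carbon

Among the measured compounds shown here, only the step from compound 1 to compound 3 bears on this change, and it was flat. On that basis no step beyond the scatter is expected from compound 1 to compound 4, and the step of no change at the digits printed from compound 1 to compound 4 (within the scatter) is estimated accordingly. For compound 4 the expected value in this assay is 70700 nM, with a range from 30000 nM to 110000 nM.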

Compound 4, half-maximal inhibitory concentration: 70700 nM
Compound 4: the middle estimate sits on the measured number at the digits printed; low and high end bracket the measured number.
By their numbers in this assay, from the lowest: compounds 1, 2, 3 and 4 (each within the scatter of the next).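

In this assay the steps of no change at the digits printed from compound 1 to compound 4 (within the scatter) and no change at the digits printed from compound 3 to compound 4 (within the scatter) show that this position, on an aromatic carbon opposite the ring nitrogen, also accepts naphthalen-1-yl with no shift in the read-out. The earlier pair showed only one halogen exchanged for another on a phenyl ring, whereas this change removes the halogen altogether and replaces the 7 heavy atoms and one aromatic ring of 4-bromophenyl with the 10 heavy atoms and 2 aromatic rings of naphthalen-1-yl. No available measurement explains why the number stays the same across these changes.

The groups shown at this position are all aromatic rings of carbon only, some carrying a halogen, so it remains open whether an amine, a carboxylic acid or a longer saturated chain there would change the value. Also open, as far as these compounds go, is whether a change elsewhere on the shared core would move the number at all.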